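Replacing Propoxycarbonyl with (Dimethylcarbamoyl)methyl on a Ring Nitrogen

The source may report more compounds than this note shows. Statements on the series, on what has been measured and on what is new or still open speak of the compounds shown alone.

Of the compounds shown here, three sharing one core have been measured in a functional assay on CHO-K1 cells for agonist activity at Glucose-dependent insulinotropic receptor (Homo sapiens), read by a luciferase reporter, with a stated time of 5 h; a lower number here means that less compound is needed, a higher number that more compound is needed for the effect. Compound 1 `CC(C)OC(=O)N1CCC(Oc2ncnc3c2CCN3c2ccc(S(C)(=O)=O)cc2)CC1` gives 126 nM, compound 2 `CC(C)OC(=O)N1CCC(Oc2ncnc3c2CCN3c2ccc(C#N)cc2F)CC1` gives 63.1 nM, and compound 3 `CCCOC(=O)N1CCC(Oc2ncnc3c2CCN3c2ccc(S(C)(=O)=O)cc2F)CC1` gives 79.4 nM. Going by the values given here, the only single-point step among them, a 2.0-fold lower number from compound 1 to compound 2 (0.30 log units; within the scatter), lies within the scatter. Compound 3 stands second highest of the three numbers, but its gaps to compound 2 and to compound 1 are both within the scatter, so the three values are indistinguishable on this evidence.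

Compound 4 `CN(C)C(=O)CN1CCC(Oc2ncnc3c2CCN3c2ccc(S(C)(=O)=O)cc2F)CC1` is unmeasured. It differs from compound 3 in one place: (dimethylcarbamoyl)methyl in place of propoxycarbonyl on an amine nitrogen in a ring. Among the compounds with values here, none of the measured steps touches this amine nitrogen in a ring, so no measured step bears on the change, and the one step that exists concerns a different part of the molecule. The expectation therefore rests on the shared core alone, with no guide to direction; a step of no more than the scatter in either direction is expected, written as a 1.4-fold higher number from compound 3 to compound 4 (0.14 log units; within the scatter). Compound 4 is estimated at 110 nM, within a range of 30 nM to 450 nM.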

Compound 4, half-maximal effective concentration: > 10000 nM
Compound 4: only a limit was reported (the forecaster's own chance of this, stated with the estimate: 5%); middle value at least 90-fold (1.95 log units) from the limit.
By their numbers in this assay, from the lowest: compounds 2, 3 and 1 (each within the scatter of the next). At a limit, above all of these: compound 4.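

In this assay, the amine nitrogen in the ring proves to be a place where the group matters greatly: (dimethylcarbamoyl)methyl in place of propoxycarbonyl gives an at least 120-fold higher number from compound 3 to compound 4 (2.10 log units; beyond the scatter), the only step shown that lies beyond the scatter. Compound 4 gives > 10000 nM, a limit of the assay and not a number: the limit of > 10000 nM in this assay, at which 1 of the 4 values shown sits. Both groups count 6 heavy atoms and neither has a ring or a net charge, so these counts do not separate a compound that gives a number from one that reaches the limit.

The compounds shown leave open how far compound 4 really lies from compound 3, and whether the carbonyl bound directly to the ring nitrogen is what counts. A urea bearing a dimethylamino group, or a simple amide at that nitrogen, would address the second question.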